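The source may hold more compounds than are shown below. What is called first, only, known or untested is meant among the compounds shown, and "the series" means these compounds.

Compound 3, `OC[C@H]1O[C@@H](n2cnc3c(SCc4ccccc4)nccc32)C[C@@H]1O`, is the compound with the highest reading among the three measured. In a functional assay (Homo sapiens) for inhibition of Nucleic Acid, tested at 100 uM (on this read-out lower numbers stand for less inhibition and higher numbers for more inhibition at the one concentration tested (going by the name of the read-out)), compound 3 gives 18%. Its two measured neighbours sit lower: compound 2, `OC[C@H]1O[C@@H](n2cnc3cnccc32)C[C@@H]1O`, gives 6%, and compound 1, `CN(C)c1nccc2c1ncn2[C@H]1C[C@H](O)[C@@H](CO)O1`, gives 0%. The two steps that lead to compound 3 both change the same aromatic carbon: a number 12 percentage points higher from compound 2 to compound 3 (beyond the scatter), and a number 18 percentage points higher from compound 1 to compound 3 (beyond the scatter). Between compounds 1 and 2 the step is a number 6 percentage points higher from compound 1 to compound 2 (within the scatter).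

Compound 4, `OC[C@H]1O[C@@H](n2cnc3c(Cl)nccc32)C[C@@H]1O`, differs from compound 3 at that same aromatic carbon: chloro in place of benzylsulfanyl on an aromatic carbon. The measured steps bear on this directly. Putting benzylsulfanyl in place of hydrogen or of dimethylamino raised inhibition by a modest amount in each case; removing it in favour of chloro, a group of a single heavy atom like the hydrogen of compound 2, is therefore expected to undo that gain. The step is estimated as a number 11 percentage points lower from compound 3 to compound 4 (beyond the scatter), downward and modest, with compound 4 expected to fall near the readings of compounds 1 and 2. Compound 4 is thus estimated at 7%, within a range of 0% to 18%.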

Compound 4, a percentage reported as inhibition, at one concentration (the size of the read-out at that concentration, not a potency): 5%
For compound 4 the middle estimate is 2 percentage points above the measured one, within the range that was stated.
By their numbers in this assay, from the lowest: compounds 1, 4 and 2 (each within the scatter of the next); then compound 3.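

In this assay, chloro at this aromatic carbon does not keep the gain seen with benzylsulfanyl: the reading is a number 13 percentage points lower from compound 3 to compound 4 (beyond the scatter), whereas it is a number 1 percentage points lower from compound 2 to compound 4 (within the scatter) and a number 5 percentage points higher from compound 1 to compound 4 (within the scatter). Among these four compounds, only benzylsulfanyl therefore sets a compound apart, while chloro, hydrogen and dimethylamino give readings that cannot be told apart. No measurement here offers an explanation for this difference.

The compounds shown leave open whether the gain belongs to the sulfur or to the six-membered aromatic ring of carbon only, a question that methylsulfanyl or benzyloxy at this carbon would separate. Going by these compounds, with compound 3 at 18% in this assay as the reference, whether a longer chain, such as phenylethylsulfanyl, would raise the reading further also remains open.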